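The source may hold more compounds than are shown below. What is called first, only, known or untested is meant among the compounds shown, and "the series" means these compounds.

Compound 1 `CC(C)=CCC/C(C)=C/CC/C(C)=C/C(=O)NC(=N)NC(=O)C=C(C)C`: 23400 nM
Compound 2 `CC(C)=CCC/C(C)=C/C(=O)NC(=N)NC(=O)/C=C(\C)CCC=C(C)C`: 46900 nM
Compound 3 `CC(C)=CCC/C(C)=C/CC/C(C)=C/C(=O)NC(=N)NC(=O)/C=C(\C)CC/C=C(\C)CCC=C(C)C`: 18500 nM

These numbers come from a functional assay on A549 cells (Homo sapiens) for inhibition, read by MTT assay, with a stated time of 72 h; a higher number here means a weaker inhibitor of growth, a lower number a stronger inhibitor of growth. Compound 3 has the lowest of the three, though its gap to compound 1 lies within the scatter; only compound 2 stands clearly higher. Compound 4 `CC(C)=CCC/C(C)=C/CC/C(C)=C/C(=O)NC(=N)NC(=O)/C=C(\C)CCC=C(C)C` differs from compound 3 by hydrogen in place of 3-methylbut-2-en-1-yl on a saturated chain carbon bound to a double-bonded chain carbon. Among the compounds with values here, the one measured step at this place, a 1.3-fold lower number from compound 1 to compound 3 (0.10 log units; within the scatter), stayed within the scatter when 3,7-dimethylocta-2,6-dien-1-yl replaced hydrogen there. Taking 3-methylbut-2-en-1-yl off compound 3 is therefore expected to shift the number little, a 1.2-fold higher number from compound 3 to compound 4 (0.08 log units; within the scatter), in no direction beyond the scatter. Compound 4 is expected to give about 22000 nM in this assay, between 10000 nM and 50000 nM.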

Compound 4, concentration for 50% growth inhibition: 38900 nM
Beside the measured number, compound 4's estimate is 1.8-fold (0.25 log units) below it, within the range that was stated.
By their numbers in this assay, from the lowest: compounds 3, 1, 4 and 2 (each within the scatter of the next, the first and the last beyond it).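

In this assay, within the data shown here, taking 3-methylbut-2-en-1-yl off a saturated chain carbon bound to a double-bonded chain carbon gives the first step at this place that passes the scatter: a 2.1-fold higher number from compound 3 to compound 4 (0.32 log units; beyond the scatter). The same group added on other partner chains moves the number far less, with a 1.7-fold higher number from compound 1 to compound 4 (0.22 log units; within the scatter) and a 1.2-fold lower number from compound 2 to compound 4 (0.08 log units; within the scatter), both within the scatter, so its effect depends on the compound that carries it. Nothing available explains this difference. As far as these compounds go, whether an amine or a carboxylic acid at the end of this chain would keep the number of compound 3 remains open.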